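This account rests on a few compounds, and the source may have more. Where it says the series, first, only, none or still open, it means among the compounds named here.

Compound 1 `COc1ccc(C2N=C(SCc3ccc(Cl)cc3)NC(C)=C2C(=O)Nc2ccc(F)cc2)cc1OC` gives 20.1% in a functional assay on the whole organism (artery, strain albino) with Rattus norvegicus as the target, with a stated time of 180 min, at a dose of 10 mg/kg by the oral route; a lower number here means less inhibition, a higher number more inhibition at the dose given (going by the name of the read-out). Compound 2 `COc1ccc(C2N=C(SCc3ccc(F)cc3)NC(C)=C2C(=O)Nc2ccc(F)cc2)cc1OC` gives 22.2% in this assay , and the step of a number 2.1 percentage points higher from compound 1 to compound 2 (within the scatter) follows from the change (fluoro in place of chloro on an aromatic carbon). Compound 3 `CC1=C(C(=O)Nc2ccc([N+](=O)[O-])cc2)C(c2ccc(Br)cc2)N=C(SCc2ccc(Cl)cc2)N1` gives 19.1% in this assay ; the difference between the core of compound 1 and the core of compound 3 is not broken down here. Compound 4 `CC1=C(C(=O)Nc2ccc([N+](=O)[O-])cc2)C(c2ccc(Br)cc2)N=C(SCc2ccc(F)cc2)N1` is not yet measured and differs from compound 3 by fluoro in place of chloro on an aromatic carbon, the same change that separates compound 1 from compound 2, at the same kind of place. Because the earlier step was a number 2.1 percentage points higher from compound 1 to compound 2 (within the scatter), the step expected for compound 4 is a number 1.9 percentage points higher from compound 3 to compound 4 (within the scatter), again within the scatter. Compound 4 is therefore estimated at 21% in this assay , between 12% and 30%.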

Compound 4, a percentage reported as inhibition, in the whole organism at one dose (the size of the read-out at that dose, not a potency): 17.5%
Beside the measured number, compound 4's estimate is 3.5 percentage points above it; the range from low to high includes it.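

On the core of compound 3, replacing 4-chlorobenzyl with 4-fluorobenzyl gives a number 1.6 percentage points lower from compound 3 to compound 4 (within the scatter) in this assay. Set beside the same change on the core of compound 1, the two steps cannot be told apart: the same change on two cores in this assay, a number 2.1 percentage points higher (within the scatter) from compound 1 to compound 2 and a number 1.6 percentage points lower (within the scatter) from compound 3 to compound 4, 3.7 percentage points apart, within the scatter of two such steps. This shows that, on these two cores, the change leaves the number within the scatter, but with one pair per core at one dose it does not show that the two cores respond alike or that the change is without effect in general.

The compounds shown leave open whether an amine or a carboxylic acid in place of the halogen would give a step beyond the scatter. Also open, on these data alone, is what a longer chain in place of the (4-fluorobenzyl)sulfanyl group would give.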